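Second chloro on the 4-chlorophenyl compound

The source may report more compounds than this note shows. Statements on the series, on what has been measured and on what is new or still open speak of the compounds shown alone.

Values in a physicochemical assay for solubility, in phosphate buffer, at pH 7.4 (on this read-out higher numbers stand for higher solubility and lower numbers for lower solubility), follow
compound 1 `CCOC(=O)c1c(-c2ccc(C(F)(F)F)cc2)[nH]c2cccc(OC)c2c1=O` gives 22000 nM
compound 2 `CCOC(=O)c1c(-c2cccc(F)c2)[nH]c2cc(OC)ccc2c1=O` gives > 100000 nM (a limit)
compound 3 `CCOC(=O)c1c(-c2ccc(Cl)cc2)[nH]c2cccc(OC)c2c1=O` gives > 100000 nM (a limit)

Compound 3 stands at > 100000 nM in this assay as a limit and not a number. Its place is therefore known only from one side, and the limit is shared widely across this small set (the limit of > 100000 nM in this assay, at which 2 of the 3 values shown sit).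

The next compound is compound 4 `CCOC(=O)c1c(-c2ccc(Cl)c(Cl)c2)[nH]c2cccc(OC)c2c1=O` and the change is chloro in place of hydrogen on an aromatic carbon. The new chloro sits ortho to a chloro group and meta to a large group, taking 4-chlorophenyl to 3,4-dichlorophenyl.

Within the data shown here, only one measured step touches this ring, namely an at least 4.5-fold higher number from compound 1 to compound 3 (0.65 log units; beyond the scatter) (chloro in place of trifluoromethyl). It is a different change and its size is only a bound, so it is weak guidance. On that single step, a lower number is expected for compound 4, moving toward compound 1 at 22000 nM in this series. The expected step is an at least 2.8-fold lower number from compound 3 to compound 4 (0.45 log units; beyond the scatter) as a rough estimate, and a reading at the limit remains possible. For compound 4 in this assay the estimated value is 35000 nM with 10000 nM to 100000 nM as the expected range.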

Compound 4, solubility: 39000 nM
Estimate against measurement, compound 4: 1.1-fold (0.05 log units) below; the measured number falls inside the stated range.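

On the 4-chlorophenyl ring, the carbon ortho to a chloro group and meta to a large group is not a silent place in this assay: chloro in place of hydrogen there gives an at least 2.5-fold lower number from compound 3 to compound 4 (0.40 log units; beyond the scatter). The earlier step on this ring exchanged one group for another, whereas this one adds a single heavy atom, and that is enough to give compound 4 a measured 39000 nM, a number and not a limit. The true size of the step remains unknown, since the value of compound 3 is a limit and not a number: the limit of > 100000 nM in this assay, at which 2 of the 4 values shown sit.

Open, on these data alone, is whether the step belongs to this particular carbon or to a second chloro anywhere on the ring, and how a nitrile, an amine or a carboxylic acid at the same place would compare with chloro. Also open, as far as these compounds go, is whether the same change gives a similar step when the methoxy group sits elsewhere on the shared core, as it does in compound 2.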